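Swapping Ethoxycarbonyl for Hydroxymethyl on a Shared Core

This account rests on a few compounds, and the source may have more. Where it says the series, first, only, none or still open, it means among the compounds named here.

Of the compounds shown here, two have so far been tested in a functional assay on SW480 cells (Homo sapiens) for cytotoxicity, read by MTT assay, with a stated time of 48 h; on this read-out lower numbers stand for stronger inhibition and higher numbers for weaker inhibition. Among the measured compounds shown here, in this test, compound 1 `COc1cc([C@@H]2C[C@@]2(CO)C(=O)Nc2ccccc2)cc(OC)c1OC` gives 76800 nM, the only actual number available. Compound 2 `CCOC(=O)[C@@]1(C(=O)NCc2ccc(C)cc2)C[C@H]1c1cc(OC)c(OC)c(OC)c1` is recorded at > 100000 nM, which is a limit of the assay and not a number. Its true position is therefore unknown.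

The next compound to be tested is compound 3 `COc1cc([C@@H]2C[C@@]2(CO)C(=O)NCc2ccc(C)cc2)cc(OC)c1OC`. It replaces the ethoxycarbonyl of compound 2 with hydroxymethyl on a saturated ring carbon, next to the ring atom that bears a large group: hydroxymethyl in place of ethoxycarbonyl on a saturated ring carbon. For the measured compounds named here, no step between measured compounds is available to show what such a replacement does in this assay, so the expectation is a cautious one. The estimate leans on compound 1 at 76800 nM, and it points towards weak inhibition. The expected change is an at least 1.4-fold lower number from compound 2 to compound 3 (0.15 log units; that floor lies within the scatter), a modest move towards stronger inhibition that may not clear the usual scatter. Compound 3 could also end at the limit of the assay. For compound 3 the estimated value is 70000 nM, with an expected range from 30000 nM to 130000 nM.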

Compound 3, half-maximal inhibitory concentration: 76300 nM
The estimate for compound 3 lay 1.1-fold (0.04 log units) below the measured number; measured number inside the range.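

With a measured number for compound 3, the replacement of ethoxycarbonyl by hydroxymethyl on a saturated ring carbon now has a step of its own in this assay: an at least 1.3-fold lower number from compound 2 to compound 3 (0.11 log units; that floor lies within the scatter). As far as these compounds go, that step gives only a floor, and its true size stays unknown, since compound 2 is recorded at a limit of the assay and not at a number: the limit of > 100000 nM in this assay, at which 1 of the 3 values shown sits. The amide side also gains its first reading with hydroxymethyl held in place, where 4-methylbenzyl in place of phenyl on an amide-type nitrogen gives a 1.0-fold lower number from compound 1 to compound 3 (0.00 log units; within the scatter), so compound 1 and compound 3 cannot be told apart in this assay.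

The compounds shown leave open whether another group on this saturated ring carbon, such as a carboxylic acid, an aminomethyl group or a longer hydroxyalkyl chain, would give a number clearly apart from those of compound 1 and compound 3. They also leave open whether a different group on the amide-type nitrogen, such as a longer alkyl chain or a 4-methoxybenzyl group, would separate from phenyl and 4-methylbenzyl in this test.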